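A few compounds are considered here, and "the series" means these few. Any claim that something is new, unique, unknown or untested is made for them only; others in the source may bear on it.

Compound 2 `CC[C@@H]1C(=O)N(C)c2cnc(-n3ccnc3-c3ccccc3)nc2N1CCC(F)(F)F` gives 9 nM in an assay on isolated protein for inhibition of serine/threonine-protein kinase PLK2 (Homo sapiens), read by TR-FRET, with a stated time of 60 min (a lower number here means a stronger inhibitor, a higher number a weaker inhibitor), and so holds the lowest of the two numbers measured, while compound 1 `CC[C@@H]1C(=O)N(C)c2cnc(-n3ccnc3-c3ccccc3)nc2N1[C@@H]1CCOC1` gives 21 nM in this assay. Compound 3 `CC[C@@H]1C(=O)N(C)c2cnc(-n3ccnc3-c3ccccc3)nc2N1[C@H]1CCOC1` carries oxolan-3-yl in place of 3,3,3-trifluoropropyl on a nitrogen on an aromatic ring in a ring. Among the measured compounds shown here, the only measured step bearing on this change, a 2.3-fold lower number from compound 1 to compound 2 (0.37 log units; beyond the scatter), runs in the opposite direction. Because a 2.3-fold lower number from compound 1 to compound 2 (0.37 log units; beyond the scatter) was only modest, the reverse exchange is expected to raise the number by a comparably modest amount in this assay. Compound 3 is therefore expected to give about 25 nM, within a range of 8 nM to 80 nM. The expected step is a 2.8-fold higher number from compound 2 to compound 3 (0.44 log units; beyond the scatter).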

Compound 3, half-maximal inhibitory concentration: 8 nM
Beside the measured number, compound 3's estimate is 3.1-fold (0.49 log units) above it; low and high end bracket the measured number.
By their numbers in this assay, from the lowest: compounds 3 and 2 (each within the scatter of the next); then compound 1.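

Compound 1's higher number does not follow from the oxolan-3-yl group as such: with the other drawn configuration at the saturated ring carbon, replacing 3,3,3-trifluoropropyl gives a 1.1-fold lower number from compound 2 to compound 3 (0.05 log units; within the scatter). In this assay, the gap of a 2.6-fold lower number from compound 1 to compound 3 (0.42 log units; beyond the scatter) can be set on that stereocentre alone, because of what this pair shares: the fact that compounds 1 and 3 differ only in the configuration as drawn

The compounds shown leave open how an amine or a longer chain on this nitrogen would read. They also leave open whether configuration matters at the ring atom that bears an ethyl group, which is the same in all three compounds.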